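Stretching the Phenyl to a Phenethyl Arm

The compounds below may be only part of what the source reports. "The series", "measured", "known", "first", "only" and "open" are said of these compounds alone.

Three hydroxamic acids have been measured in an assay on isolated protein for inhibition of sphingomyelin phosphodiesterase (Homo sapiens), read by fluorescence, with a stated time of 30 min; a lower number here means a stronger inhibitor, a higher number a weaker inhibitor. Compound 1 `O=C(NO)c1cccc(OCc2ccc(-c3ccccc3)cc2)c1` gives 19600 nM in this assay. Compound 2 `COc1ccc(C(=O)NO)cc1OCc1ccc(-c2cccnc2)cc1` gives 4970 nM in this assay. Compound 3 `O=C(NO)c1cccc(OCc2ccc(-c3noc(-c4ccccc4)n3)cc2)c1` reaches only the upper limit of this assay, reported as > 100000 nM, so its inhibition is too weak to be put into a number. That situation is described by the limit of > 100000 nM in this assay, at which 1 of the 3 values shown sits, and it places compound 3 below the two compounds that did give a number.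

Compound 4 `O=C(NO)c1cccc(OCc2ccc(-c3noc(CCc4ccccc4)n3)cc2)c1` has not yet been measured. It is built from compound 3 by one change, (phenethyl in place of phenyl on an aromatic carbon), that is, phenethyl in place of phenyl on an aromatic carbon. Among the measured compounds shown here, no measured pair in this set shows what such a change does, so the direction of the step rests on compound 3 alone. Because compound 3 already sits at the limit, shown by the limit of > 100000 nM in this assay, at which 1 of the 3 values shown sits, the most likely outcome is that compound 4 stays near that limit as well, with no step beyond the scatter expected.

The estimate for compound 4 is therefore 100000 nM, within a range from 20000 nM to 500000 nM, which corresponds to an expected step of a number no higher from compound 3 to compound 4 (the limit leaves the size open).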

Compound 4, half-maximal inhibitory concentration: 1730 nM
Estimate against measurement, compound 4: 58-fold (1.76 log units) above; measured number outside the range, below it.
By their numbers in this assay, from the lowest: compound 4; then compound 2; then compound 1. At a limit, above all of these: compound 3.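

Phenethyl in place of phenyl on this aromatic carbon keeps the same six-membered aromatic ring of carbon only but carries it on 8 heavy atoms rather than 6, and in this assay it gives an at least 57-fold lower number from compound 3 to compound 4 (1.76 log units; beyond the scatter). This shows that the position is not closed to activity: the group on the five-membered aromatic ring can decide whether a compound gives a number at all in this assay. The exact size of the step cannot be fixed, since compound 3 sits at a limit and not at a number: the limit of > 100000 nM in this assay, at which 1 of the 4 values shown sits.

The compounds shown place only phenyl and phenethyl on this carbon, so it remains open how the result depends on chain length, which a benzyl group or a longer phenylpropyl chain would test, and whether an amine or a carboxylic acid on the end of the chain would be tolerated. They also leave open whether the same change would give a step of similar size on a different core, such as the core of compound 2.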